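Swapping a Naphthyl for a Methoxyphenyl on a Fused Core

The source may report more compounds than this note shows. Statements on the series, on what has been measured and on what is new or still open speak of the compounds shown alone.

For the measured compounds named here, compound 2 `Cc1nc2c3ccccc3ccc2c2nc3c(ccc4ccccc43)c(-c3cccc4ccccc34)c12` is the only compound here with a numeric result in a functional assay on HCT-116 cells (Homo sapiens) for cytotoxicity, read by MTT assay, with a stated time of 48 h; on this read-out higher numbers stand for weaker inhibition and lower numbers for stronger inhibition; compound 2 gives 20800 nM. Compound 1 `Cc1nc2c3ccccc3ccc2c2nc3c(ccc4ccccc43)c(-c3ccccc3)c12` carries phenyl where compound 2 carries naphthalen-1-yl. In this assay compound 1 reaches only the limit > 80000 nM, which is a boundary of the assay rather than a number. The step of an at least 3.8-fold lower number from compound 1 to compound 2 (0.58 log units; beyond the scatter) shows that the two-ring group went with a lower number. Compound 3 `COc1ccc(-c2c3ccc4ccccc4c3nc3c2c(C)nc2c4ccccc4ccc32)cc1` differs from compound 2 by 4-methoxyphenyl in place of naphthalen-1-yl on an aromatic carbon. Going by the values given here, this change goes back to a single six-membered ring, now bearing a methoxy, so the step from compound 1 to compound 2 is the only guide, and it points the other way. The number for compound 3 is therefore expected to rise, with a 2.4-fold higher number from compound 2 to compound 3 (0.38 log units; beyond the scatter) being the estimated step. Compound 3 is estimated at 50000 nM, with a range from 15000 nM to 90000 nM, and a result reported only as a limit is a real possibility.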

Compound 3, half-maximal inhibitory concentration: > 80000 nM
Compound 3: only a limit was reported (the forecaster's own chance of this, stated with the estimate: 40%); middle value at least 1.6-fold (0.20 log units) away from the limit.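

On the aromatic carbon opposite the ring nitrogen, replacing naphthalen-1-yl with 4-methoxyphenyl gives an at least 3.8-fold higher number from compound 2 to compound 3 (0.58 log units; beyond the scatter). A methoxy on a single six-membered ring therefore does not match the two-ring group in this assay, and among the three groups shown at this position, only naphthalen-1-yl gives a numeric result. The results for compound 1 and compound 3 are both limits rather than numbers, so the steps between them cannot be read and the effect of adding the methoxy stays hidden because of this shared limit: the limit of > 80000 nM in this assay, at which 2 of the 3 values shown sit.

Going by these compounds, it remains open whether the second aromatic ring itself matters or whether other groups at this carbon could do as well, such as naphthalen-2-yl, an amine or a carboxylic acid. A methoxy on naphthalen-1-yl would also show whether this group has the same effect on the two-ring system.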